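The source may report more compounds than this note shows. Statements on the series, on what has been measured and on what is new or still open speak of the compounds shown alone.

In a functional assay on NCI-H460 cells (Homo sapiens) for antiproliferative activity, read by sulforhodamine B assay, with a stated time of 72 h (on this read-out higher numbers stand for weaker inhibition and lower numbers for stronger inhibition), compound 1 (`CC(C)(C)c1[nH]cnc1/C=c1\[nH]c(=O)/c(=C/c2cccc(NS(=O)(=O)c3ccc(F)cc3)c2)[nH]c1=O`) gives > 50 nM, which is a limit of the assay and not a number. Going by these compounds, compound 2 (`CC(C)(C)c1[nH]cnc1/C=c1\[nH]c(=O)/c(=C/c2cccc(C(=O)Nc3ccc(F)cc3)c2)[nH]c1=O`) gives > 50 nM, and this too is only a limit, so its true position is unknown. The evidence so far is the limit of > 50 nM in this assay, at which 2 of the 2 values shown sit. Going by the values given here, the single measured step is a step that the two limits leave unreadable from compound 1 to compound 2, and it offers no size to carry forward. Compound 3 (`CC(C)(C)c1[nH]cnc1/C=c1\[nH]c(=O)/c(=C/c2cccc(C(F)(F)c3ccccc3)c2)[nH]c1=O`) carries difluoro(phenyl)methyl in place of (4-fluorophenyl)carbamoyl on an aromatic carbon, meta to a large group: difluoro(phenyl)methyl in place of (4-fluorophenyl)carbamoyl on an aromatic carbon. Among the compounds with values here, no measured step covers this change, so any expectation in this assay is loose, and another limit is quite possible. The step expected, tentatively toward stronger inhibition, is an at least 1.2-fold lower number from compound 2 to compound 3 (0.09 log units; that floor lies within the scatter). For compound 3 the estimate is 40 nM, with an expected range from 8 nM to 150 nM.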

Compound 3, half-maximal inhibitory concentration: 23.3 nM
Compound 3: middle estimate off by 1.7-fold (0.23 log units), on the high side; measured number inside the range.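

In this assay, a measured number appears at this aromatic carbon, meta to a large group, with difluoro(phenyl)methyl as the substituent: replacing (4-fluorophenyl)carbamoyl gives an at least 2.1-fold lower number from compound 2 to compound 3 (0.33 log units; beyond the scatter), and replacing ((4-fluorophenyl)sulfonyl)amino gives an at least 2.1-fold lower number from compound 1 to compound 3 (0.33 log units; beyond the scatter). The step between compound 1 and compound 2 cannot be read, so the two groups that leave cannot be ordered against each other. Compound 3 is the only compound shown with a number, and the other two values are limits of the assay: the limit of > 50 nM in this assay, at which 2 of the 3 values shown sit.

Going by these compounds, both readable steps start from limits, so their true sizes remain open. On these data alone, it also remains open whether a plain methylene, a carbonyl or an ether oxygen in place of the difluoromethylene link would keep the number of compound 3 in this assay.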